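The source may report more compounds than this note shows. Statements on the series, on what has been measured and on what is new or still open speak of the compounds shown alone.

Of the compounds shown here, three that share one core have been tested in an ADME assay on Akata cells (Homo sapiens) for cytotoxicity, with a stated time of 7 days; on this read-out higher numbers stand for lower toxicity in this test and lower numbers for higher toxicity in this test. Compound 1 `CCOc1nc(N)nc2c1ncn2/C=C1/CC1(CO)CO` gives > 20000 nM, which is a limit of the assay and not a number. Compound 2 `CC(C)Nc1nc(N)nc2c1ncn2/C=C1/CC1(CO)CO` gives > 24000 nM, also a limit. Compound 3 `CC(C)CNc1nc(N)nc2c1ncn2/C=C1/CC1(CO)CO` gives > 24000 nM, again a limit, so compound 3 has no exact number of its own.

Compound 4 `CCCOc1nc(N)nc2c1ncn2/C=C1/CC1(CO)CO` has propoxy in place of isobutylamino on an aromatic carbon.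

The nearest measured change is a step that the two limits leave unreadable from compound 1 to compound 3, where ethoxy gives way to isobutylamino. Two more bear on it: a step that the two limits leave unreadable from compound 1 to compound 2 and a step that the two limits leave unreadable from compound 2 to compound 3. None of these has a readable size, so none points in either direction. Swapping an amino chain for an alkoxy chain has therefore shown no measurable change so far, and no step beyond the scatter is expected.

The expected change is a number no higher from compound 3 to compound 4 (the limit leaves the size open), with no direction favoured. For compound 4 the estimate is 24000 nM, with an expected range from 10000 nM to 50000 nM.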

Compound 4, half-maximal cytotoxic concentration: > 20000 nM
Compound 4 was reported as a limit; the forecaster's own chance of this, stated with the estimate: 75%; the middle value does not contradict the limit.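

Compound 4 is reported only as a limit in this assay, as are compound 1, compound 2 and compound 3, so no step among these compounds can be read. The compounds shown leave open whether the ethoxy, propoxy, isopropylamino and isobutylamino chains differ at all in toxicity in this test.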